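Swapping the Furan for a Difluorophenyl on the Hydrazone Arm

A few compounds are considered here, and "the series" means these few. Any claim that something is new, unique, unknown or untested is made for them only; others in the source may bear on it.

Three measured compounds share one core and differ only in the aromatic ring attached to a carbon with a double bond to nitrogen. Compound 1 `Cn1c(=O)c(=O)n(C2CCCC2)c2nc(N/N=C/c3ccc(Cl)cc3)ncc21` carries a 4-chlorophenyl there and gives 8420 nM in a functional assay on PC-3 cells (Homo sapiens) for antiproliferative activity, read by MTT assay; on this read-out lower numbers stand for stronger inhibition and higher numbers for weaker inhibition. Compound 3 `Cn1c(=O)c(=O)n(C2CCCC2)c2nc(N/N=C/c3cc(C(F)(F)F)cc(C(F)(F)F)c3)ncc21` carries a phenyl bearing two trifluoromethyl groups and gives 8200 nM in this assay. Compound 2 `Cn1c(=O)c(=O)n(C2CCCC2)c2nc(N/N=C/c3ccco3)ncc21` carries a furan-2-yl and gives 72200 nM in this assay, the highest of the three numbers, with its steps to both other compounds beyond the scatter, so it is the weakest of the set.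

The new compound 4 `Cn1c(=O)c(=O)n(C2CCCC2)c2nc(N/N=C/c3ccc(F)cc3F)ncc21` changes compound 2 in one place: 2,4-difluorophenyl in place of furan-2-yl on a carbon with a double bond to nitrogen. Within the data shown here, the only measured step that bears on this change ran the other way, with a furan entering for a chlorinated phenyl: an 8.6-fold higher number from compound 1 to compound 2 (0.93 log units; beyond the scatter). Returning a halogenated phenyl is expected to undo most of that loss, since compound 1 at 8420 nM and compound 3 at 8200 nM sit close together despite their different substituents. Compound 4 is therefore expected to give 10000 nM, within 4000 nM to 30000 nM. That would mean an expected step of a 7.2-fold lower number from compound 2 to compound 4 (0.86 log units; beyond the scatter) toward stronger inhibition in this assay.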

Compound 4, half-maximal inhibitory concentration: 13200 nM
Estimate against measurement, compound 4: 1.3-fold (0.12 log units) below; the range from low to high includes it.
By their numbers in this assay, from the lowest: compounds 3, 1 and 4 (each within the scatter of the next); then compound 2.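

Replacing furan-2-yl with 2,4-difluorophenyl on the carbon with a double bond to nitrogen gives a 5.5-fold lower number from compound 2 to compound 4 (0.74 log units; beyond the scatter) in this assay, so the furan-2-yl compound's weak result can be recovered with a ring that contains fluorine instead of the chlorine of the earlier comparison. Exchanging 4-chlorophenyl for 2,4-difluorophenyl gives a 1.6-fold higher number from compound 1 to compound 4 (0.20 log units; within the scatter), which means that this read-out cannot tell these two rings apart. With the phenyl bearing two trifluoromethyl groups also grouped with them, all three substituted phenyl rings now lie within the scatter of one another in an unbroken chain, and among these four compounds only furan-2-yl stands clearly apart, which suggests that this position tolerates quite different substituents on a phenyl ring.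

The compounds shown leave open whether a phenyl ring with no substituent, or one bearing an amine or a carboxylic acid, would stay with this group or fall toward the furan-2-yl compound. Nothing available here explains why the furan-2-yl compound differs from the three phenyl compounds.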